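From dimethoxyphenyl to dihydroxyphenyl in a long-chain cytotoxic compound

The source may report more compounds than this note shows. Statements on the series, on what has been measured and on what is new or still open speak of the compounds shown alone.

Measured so far in a functional assay on A2780 cells (Homo sapiens) for cytotoxicity; on this read-out higher numbers stand for weaker inhibition and lower numbers for stronger inhibition:
- Compound 1 `COc1cc(O)cc(CCCCCCC/C=C\CCCCCCCc2cc(OC)cc(OC)c2)c1`: 9.8 ug/mL
- Compound 2 `CC(=O)Oc1cc(O)cc(CCCCCCC/C=C\CCCCCCCc2cc(O)cc(O)c2)c1`: 10.2 ug/mL

These two values lie within the usual scatter of repeated measurements, so compound 1 cannot be ranked against compound 2, even though the two structures differ in more than one place.

Compound 3 `COc1cc(O)cc(CCCCCCC/C=C\CCCCCCCc2cc(O)cc(O)c2)c1` is compound 1 with one change: 3,5-dihydroxyphenyl in place of 3,5-dimethoxyphenyl on a saturated chain carbon, seven bonds along the chain from a double-bonded chain carbon. The 3,5-dihydroxyphenyl group takes the place of 3,5-dimethoxyphenyl on a saturated chain carbon, seven bonds along the chain from a double-bonded chain carbon.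

For the measured compounds named here, no measured pair shows this change alone, so the expectation rests on thin evidence. Compound 2 already carries a 3,5-dihydroxyphenyl group and still gives 10.2 ug/mL, which suggests that this group need not move the number much. In this assay, the expectation is therefore a small shift towards a lower number, probably none beyond the scatter. The expected step is a 1.2-fold lower number from compound 1 to compound 3 (0.09 log units; within the scatter). For compound 3 the estimated value is 8 ug/mL, with an expected range from 3.5 ug/mL to 18 ug/mL.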

Compound 3, half-maximal inhibitory concentration: 10 ug/mL
Estimate against measurement, compound 3: 1.3-fold (0.10 log units) below; the range from low to high includes it.
By their numbers in this assay, from the lowest: compounds 1, 3 and 2 (each within the scatter of the next).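

In this assay, placing 3,5-dihydroxyphenyl where 3,5-dimethoxyphenyl stood, on a saturated chain carbon, seven bonds along the chain from a double-bonded chain carbon, gives a 1.0-fold higher number from compound 1 to compound 3 (0.01 log units; within the scatter), so this end of the molecule takes the change with no readable shift, even though the entering group has 2 hydrogen-bond donors and the leaving group has 0. Compound 3 also provides a single-change link to compound 2, which the first two compounds could not offer: methyl in place of acetyl on an oxygen on an aromatic ring gives a 1.0-fold lower number from compound 2 to compound 3 (0.01 log units; within the scatter), again with no readable shift. Nothing measured here explains why either change leaves the number in place.

Still open, going by these compounds, is whether this end of the molecule would accept a very different group, such as a carboxylic acid or an amine in place of the 3,5-dihydroxyphenyl group, without a step beyond the scatter. On these data alone, it is equally open whether a shorter chain, or a chain without its double bond, would move the number in this assay.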